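Swapping pyridine for furan on a liver cell toxicity test

The source may report more compounds than this note shows. Statements on the series, on what has been measured and on what is new or still open speak of the compounds shown alone.

Four compounds built on one shared core are compared here in an ADME assay on HepG2 2.2.15 cells (Homo sapiens) for cytotoxicity, read by MTT assay; on this read-out higher numbers stand for lower toxicity in this test and lower numbers for higher toxicity in this test. Compound 1 `C=C1CC[C@@H]2[C@](C)(COC(=O)c3cccnc3)[C@H](O)CC[C@@]2(C)[C@@H]1C/C=C1\C=COC1=O` gives 2050000 nM. Compound 2 `C=C1CC[C@@H]2[C@](C)(COC(=O)c3ccco3)[C@H](O)CC[C@@]2(C)[C@@H]1C/C=C1\C=COC1=O` differs from compound 1 by furan-2-yl in place of pyridin-3-yl on a carbonyl carbon. For compound 2 the assay reports only a limit, > 2150000 nM, which is the limit of > 2150000 nM in this assay, at which 1 of the 3 values shown sits. Between them the change made an at least 1.0-fold higher number from compound 1 to compound 2 (0.02 log units; that floor lies within the scatter), so the two values cannot be told apart on this read-out.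

Compound 3 `C=C1CC[C@@H]2[C@](C)(CO)[C@H](OC(=O)c3cccnc3)CC[C@@]2(C)[C@@H]1C/C=C1\C=COC1=O` has the same atoms as compound 1 joined differently; the difference between the two cores is not broken down here. In this assay compound 3 gives 337000 nM, the lowest number among the two compounds with a number, with compound 1 as its nearest neighbour.

Compound 4 `C=C1CC[C@@H]2[C@](C)(CO)[C@H](OC(=O)c3ccco3)CC[C@@]2(C)[C@@H]1C/C=C1\C=COC1=O` has not yet been measured. It differs from compound 3 by furan-2-yl in place of pyridin-3-yl on a carbonyl carbon, the same change that separates compound 1 from compound 2, set at the same kind of place. From compound 3 to compound 4 the step is expected to be about a 1.2-fold higher number from compound 3 to compound 4 (0.07 log units; within the scatter), resting on the earlier change, which gave an at least 1.0-fold higher number from compound 1 to compound 2 (0.02 log units; that floor lies within the scatter), and on the starting value of compound 3, 337000 nM. For compound 4 the expected value is 400000 nM, with a likely range from 170000 nM to 1000000 nM.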

Compound 4, half-maximal cytotoxic concentration: 42000 nM
Compound 4: the middle estimate sits 9.5-fold (0.98 log units) above what was measured; the whole stated range lies above it.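

In this assay, furan-2-yl in place of pyridin-3-yl on a carbonyl carbon gives an 8.0-fold lower number from compound 3 to compound 4 (0.90 log units; beyond the scatter), so on the core of compound 3 this swap goes with higher toxicity in this test. Set beside the earlier step on the core of compound 1, the same swap does not carry over from one core to the other, and its effect here cannot be read across between these two pairs: the same change on two cores in this assay, an at least 1.0-fold higher number (0.02 log units; that floor lies within the scatter) from compound 1 to compound 2 and an 8.0-fold lower number (0.90 log units; beyond the scatter) from compound 3 to compound 4, at least 8.4-fold (0.92 log units) apart, beyond the scatter of two such steps The pairs show that the result of this swap depends on the core in these four compounds, but they give no reason for the gap and no rule for other cores, and one side of the comparison, compound 2, is a limit of the assay and not a number: the limit of > 2150000 nM in this assay, at which 1 of the 4 values shown sits.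

The compounds shown leave open whether the drop belongs to furan-2-yl alone, since a phenyl ring or a thiophen-2-yl ring on the same carbonyl carbon could land close to either compound 3 or compound 4. They also leave open how a simple acetyl group, or a longer alkyl chain, would behave in that place on each of the two cores.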